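Moving the nitro group from compound 3 to compound 4

The source may report more compounds than this note shows. Statements on the series, on what has been measured and on what is new or still open speak of the compounds shown alone.

For the measured compounds named here, in a functional assay on MCF7 cells (Homo sapiens) for cytotoxicity, read by MTT assay, with a stated time of 96 h (on this read-out higher numbers stand for weaker inhibition and lower numbers for stronger inhibition), three compounds built on a shared core have numbers so far. Compound 1 `COc1cc(C(=O)c2cn(-c3cccc(C)c3)cc2-c2ccc([N+](=O)[O-])cc2)cc(OC)c1OC` gives 780 nM, compound 2 `COc1cc(C(=O)c2cn(-c3ccc(C)cc3)cc2-c2ccc([N+](=O)[O-])cc2)cc(OC)c1OC` gives 200 nM, and compound 3 `COc1cc(C(=O)c2cn(-c3ccc(F)cc3)cc2-c2ccccc2[N+](=O)[O-])cc(OC)c1OC` gives 38 nM, the lowest of the three numbers. Compound 4 `COc1cc(C(=O)c2cn(-c3ccc(F)cc3)cc2-c2ccc([N+](=O)[O-])cc2)cc(OC)c1OC` has the same atoms as compound 3, joined differently: 4-nitrophenyl in place of 2-nitrophenyl on an aromatic carbon. In short, 4-nitrophenyl stands in place of 2-nitrophenyl on an aromatic carbon.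

Going by the values given here, no measured step makes this change directly. Among the compounds with values here, the only measured step, a 3.9-fold lower number from compound 1 to compound 2 (0.59 log units; beyond the scatter), puts 4-methylphenyl in place of 3-methylphenyl on an aromatic nitrogen, so it shows only that a change of this size can register beyond the scatter. The better guide is a comparison of values. Compound 4 differs only in bearing a 4-fluorophenyl group where compound 2, at 200 nM, bears 4-methylphenyl. How these two groups compare has not been measured, which keeps the range wide.

A move towards a higher number, meaning weaker inhibition, is therefore expected, with an estimated 4.5-fold higher number from compound 3 to compound 4 (0.65 log units; beyond the scatter). For compound 4 the estimate in this assay is 170 nM, with an expected range of 50 nM to 550 nM.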

Compound 4, half-maximal inhibitory concentration: 240 nM
Beside the measured number, compound 4's estimate is 1.4-fold (0.15 log units) below it, within the range that was stated.
By their numbers in this assay, from the lowest: compound 3; then compounds 2 and 4 (each within the scatter of the next); then compound 1.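

In this assay, for the compounds shown here, the position on an aromatic carbon of the five-membered ring is for the first time read on its own for the nitro group: a 6.3-fold higher number from compound 3 to compound 4 (0.80 log units; beyond the scatter), so with 4-fluorophenyl held on the ring nitrogen, the 2-nitrophenyl group gives the lower number of the pair. The other half of the molecule now reads more clearly as well: with 4-nitrophenyl held in place, a 1.2-fold higher number from compound 2 to compound 4 (0.08 log units; within the scatter), so fluoro in place of methyl on that aromatic carbon cannot be told apart from the scatter, whereas a 3.3-fold lower number from compound 1 to compound 4 (0.51 log units; beyond the scatter), which places 4-fluorophenyl where 3-methylphenyl stood on the ring nitrogen. Nothing given here accounts for the gap between the 2-nitrophenyl and 4-nitrophenyl compounds.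

The compounds shown leave open whether the lower number seen with 2-nitrophenyl carries over when 4-methylphenyl or 3-methylphenyl sits on the ring nitrogen. They also leave open how an amine or a carboxylic acid in place of the nitro group would read in this assay, and so whether the nitro group itself is needed at all.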